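A few compounds are considered here, and "the series" means these few. Any claim that something is new, unique, unknown or untested is made for them only; others in the source may bear on it.

Measured so far in a functional assay on CHO cells for antagonist activity at Orexin/Hypocretin receptor type 1 (Homo sapiens), read by FLIPR and calcium flux; a lower number here means a stronger inhibitor, a higher number a weaker inhibitor:

Compound 1, `CCn1nc(C)c2c1CCN(C(C(=O)NC)c1ccccc1)C2CCc1ccc(Cl)cc1`: 993 nM
Compound 2, `CCn1nc(C)c2c1CCN(C(C(=O)NC)c1ccccc1)C2CCc1ccccc1F`: 669 nM

Compound 2 gives the lowest of the two numbers shown; its nearest neighbour is compound 1, and the step of a 1.5-fold lower number from compound 1 to compound 2 (0.17 log units; within the scatter) lies within the scatter, so the two cannot be ordered on the present data.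

The next compound in the series is compound 3, `CCn1nc(C)c2c1CCN(C(C(=O)NC)c1ccccc1)C2CCc1cccc(F)c1`. Its difference from compound 2 is 3-fluorophenyl in place of 2-fluorophenyl on a saturated chain carbon, two bonds along the chain from a saturated ring carbon; cut one bond further out, the same difference reads 2-fluorobenzyl to 3-fluorobenzyl.

Within the data shown here, only one measured step exists for comparison, and it does not bear closely on this change: a 1.5-fold lower number from compound 1 to compound 2 (0.17 log units; within the scatter) exchanges a chlorine-bearing ring for a fluorine-bearing ring and moves the halogen at the same time, whereas the step to compound 3 keeps the fluorine and changes only where it sits on the ring. Among the measured compounds shown here, no measured pair isolates that move. Both measured variants of this ring sit within the scatter of each other, which gives no indication that the ring substituent pattern moves this assay strongly.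

The expectation for the step to compound 3 is therefore none beyond the scatter, a 1.1-fold higher number from compound 2 to compound 3 (0.05 log units; within the scatter), with the range widened for lack of a directly comparable step. Compound 3 is estimated at 750 nM, between 250 nM and 2200 nM.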

Compound 3, half-maximal inhibitory concentration: 402 nM
Compound 3: the middle estimate sits 1.9-fold (0.27 log units) above what was measured; the range from low to high includes it.
By their numbers in this assay, from the lowest: compounds 3, 2 and 1 (each within the scatter of the next, the first and the last beyond it).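

In this assay, moving the fluorine alone, from 2-fluorophenyl to 3-fluorophenyl on a saturated chain carbon, two bonds along the chain from a saturated ring carbon, gives a 1.7-fold lower number from compound 2 to compound 3 (0.22 log units; within the scatter), so the two fluorine placements cannot be ordered on these data. The series does, however, now hold its first step beyond the scatter at this position, a 2.5-fold lower number from compound 1 to compound 3 (0.39 log units; beyond the scatter), which shows that the choice of aryl group can register in this assay, if only modestly; that step changes the halogen and its ring position together, so the contribution of each stays unresolved, and compound 2 lies within the scatter of both compound 1 and compound 3. No available measurement explains either step.

Going by these compounds, whether a halogen is needed at all remains open, as an unsubstituted phenyl ring, or a methoxy group or nitrile in place of the fluorine, would address that question. Also open, on these data alone, is how far this position tolerates larger changes, such as a longer chain or a pyridine ring in place of the fluorophenyl, and whether the small differences seen here persist with changes elsewhere on the shared core.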